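The compounds below may be only part of what the source reports. "The series", "measured", "known", "first", "only" and "open" are said of these compounds alone.

Measured compounds in this set:
compound 1 `COc1ccc(N/C(CCNC2=CC(=O)c3ccccc3C2=O)=N\S(=O)(=O)c2ccc(C)cc2)cc1` — 35100 nM
compound 2 `Cc1ccc(S(=O)(=O)/N=C(/CCNC2=CC(=O)c3ccccc3C2=O)Nc2ccc(Cl)cc2)cc1` — 65400 nM
compound 3 `Cc1ccc(S(=O)(=O)/N=C(/CCNC2=CC(=O)c3ccccc3C2=O)Nc2ccc(F)c(F)c2)cc1` — 55200 nM

In an ADME assay on HEK293 cells (Homo sapiens) for cytotoxicity, read by MTT assay, with a stated time of 48 h (a lower number here means a stronger inhibitor, a higher number a weaker inhibitor), compound 1 gives 35100 nM, the smallest of the three numbers shown, but a 1.9-fold higher number from compound 1 to compound 2 (0.27 log units; within the scatter) and a 1.6-fold higher number from compound 1 to compound 3 (0.20 log units; within the scatter) both fall within the scatter, so the three compounds are not separated by this assay. The next compound, compound 4 `Cc1ccc(S(=O)(=O)/N=C(/CCNC2=CC(=O)c3ccccc3C2=O)Nc2ccc(Cl)cc2Cl)cc1`, changes the group on the amine nitrogen of the shared core: 2,4-dichlorophenyl in place of 4-methoxyphenyl on an amine nitrogen.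

Within the data shown here, the steps that bear on this are those in which the same aryl group on the amine nitrogen was changed. Replacing methoxy by chloro gave a 1.9-fold higher number from compound 1 to compound 2 (0.27 log units; within the scatter); moving to the 3,4-difluorophenyl gave a 1.6-fold higher number from compound 1 to compound 3 (0.20 log units; within the scatter); and between the two halogenated compounds the gap was a 1.2-fold lower number from compound 2 to compound 3 (0.07 log units; within the scatter). Among the measured compounds shown here, none of these exceeds the scatter, and no measured step covers a second chlorine on the phenyl ring, so nothing in the data points to a shift in either direction beyond the scatter.

Compound 4 is therefore expected to sit close to compound 1, with an estimated 1.4-fold higher number from compound 1 to compound 4 (0.15 log units; within the scatter), most likely toward the side of the halogenated compounds 2 and 3, giving an estimate of 50000 nM with a range from 22000 nM to 115000 nM.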

Compound 4, half-maximal inhibitory concentration: 41900 nM
The estimate for compound 4 lay 1.2-fold (0.08 log units) above the measured number; low and high end bracket the measured number.
By their numbers in this assay, from the lowest: compounds 1, 4, 3 and 2 (each within the scatter of the next).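

Working notes on the aryl group on the amine nitrogen: in this assay, the 2,4-dichlorophenyl group does not separate from the 4-methoxyphenyl group, with a 1.2-fold higher number from compound 1 to compound 4 (0.08 log units; within the scatter). The second chlorine gives the series its first step at a single aromatic carbon with hydrogen as the starting point, and it reads a 1.6-fold lower number from compound 2 to compound 4 (0.19 log units; within the scatter), while the comparison with the 3,4-difluorophenyl group reads a 1.3-fold lower number from compound 3 to compound 4 (0.12 log units; within the scatter). All four aryl groups on this nitrogen now fall within the scatter in this assay, including a group with two chlorines, and no available evidence speaks to the reason for these small steps.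

Open, as far as these compounds go, is whether a carboxylic acid or an amine on the phenyl ring, or a simple alkyl group such as cyclohexyl in place of the aryl group on the amine nitrogen, would move the number beyond the scatter. The compounds shown also do not tell what a longer chain in the shared core would do to the number in this assay.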